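The compounds below may be only part of what the source reports. "The series", "measured", "known", "first", "only" and "open" are said of these compounds alone.

Measured compounds:
compound 1 `COc1ccc2c(OCCn3c(=O)oc4cc(C)ccc43)ccnc2c1`: in a functional assay on EBC-1 cells (Homo sapiens) for inhibition, read by sulforhodamine B assay, with a stated time of 72 h (on this read-out higher numbers stand for weaker inhibition and lower numbers for stronger inhibition), compound 1 gives > 500 nM, a limit of the assay.
compound 2 `COc1ccc2c(OCCn3c(=O)oc4ccc(F)cc43)ccnc2c1`: compound 2 gives > 500 nM, again a limit.
compound 3 `COc1ccc2c(OCCn3c(=O)oc4cc(N)ccc43)ccnc2c1`: compound 3 gives 160 nM.

Compound 2 therefore sits at the limit, as does compound 1; only compound 3 gives a resolved number. Going by the values given here, the single measured step that resolves, an at least 3.1-fold lower number from compound 1 to compound 3 (0.49 log units; beyond the scatter), shows that exchanging a substituent on the fused ring of the shared core can carry a compound out of the region described by the limit of > 500 nM in this assay, at which 2 of the 3 values shown sit.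

The next compound, compound 4 `COc1ccc2c(OCCn3c(=O)oc4ccc(-c5cnn(C)c5)cc43)ccnc2c1`, differs from compound 2 in 1-methyl-1H-pyrazol-4-yl in place of fluoro on an aromatic carbon. Among the compounds with values here, no measured pair shows this particular exchange, and the amino group of compound 3 stands at a different place on the ring, so the step from compound 1 to compound 3 bears on it only as an indication that substituents on this ring move the read-out, and that moving away from the groups of compounds 1 and 2 has so far gone toward stronger inhibition.

Compound 4 is expected to leave the limit region, with an estimated at least 8.3-fold lower number from compound 2 to compound 4 (0.92 log units; beyond the scatter). The estimate for compound 4 is 60 nM, expected between 15 nM and 300 nM.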

Compound 4, half-maximal inhibitory concentration: > 500 nM
Compound 4: no number, only a limit; the forecaster's own chance of this, stated with the estimate: 15%; middle value at least 8.3-fold (0.92 log units) from the limit.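

In this assay compound 4 gives > 500 nM, a limit of the assay, and compound 2 also stands at a limit, so the step between compound 2 and compound 4 cannot be read: the limit of > 500 nM in this assay, at which 3 of the 4 values shown sit.

The compounds shown leave open whether 1-methyl-1H-pyrazol-4-yl in place of fluoro changes the read-out at all.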